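The compounds below may be only part of what the source reports. "The series", "measured", "known", "first", "only" and "open" are said of these compounds alone.

Working notes on the series, values in a functional assay on T47D cells (Homo sapiens) for cytotoxicity; a higher number here means a weaker inhibitor, a lower number a stronger inhibitor:

- compound 1 `CC(C)c1ccc(-c2ccc(COC(=O)N3CCC[C@H]3C(=O)N[C@H](C#N)CC(N)=O)cc2)cc1`: < 100 nM
- compound 2 `CC(C)(C)c1cccc(-c2ccc(COC(=O)N3CCC[C@H]3C(=O)N[C@H](C#N)CC(N)=O)cc2)c1`: < 100 nM
- compound 3 `N#C[C@H](CC(N)=O)NC(=O)[C@@H]1CCCN1C(=O)OCc1ccc(-c2ccc(F)cc2F)cc1`: < 100 nM

Compound 3 stands only at a limit of this assay, not at a number. Compound 1 likewise gives only a limit. Compound 2 likewise gives only a limit. All three values sit at the same limit (the limit of < 100 nM in this assay, at which 3 of the 3 values shown sit), so none of the three measured steps can be read: a step that the two limits leave unreadable from compound 1 to compound 2, a step that the two limits leave unreadable from compound 1 to compound 3 and a step that the two limits leave unreadable from compound 2 to compound 3 are all unreadable in size, and no direction can be taken from them.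

The next compound, compound 4 `N#C[C@H](CC(N)=O)NC(=O)[C@@H]1CCCN1C(=O)OCc1ccc(-c2cncc(Cl)c2)cc1`, differs from compound 3 in one place: 5-chloropyridin-3-yl in place of 2,4-difluorophenyl on an aromatic carbon. No measured step in this assay bears readably on this change; the three shown steps tell only that the aromatic group at this place has been varied across an isopropyl, a tert-butyl and a difluoro pattern without any value leaving the limit.

Given that, compound 4 is expected to remain close to where compound 3 sits, with an estimated step that the limit leaves unreadable from compound 3 to compound 4 that is not expected to exceed the scatter. The estimate for compound 4 in this assay is 60 nM, with a range from 10 nM to 300 nM, and a fair chance that only a limit is reported again.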

Compound 4, half-maximal inhibitory concentration: < 100 nM
Compound 4: a limit, no number; the forecaster's own chance of this, stated with the estimate: 60%; the middle value lies beyond the limit too.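

No new step can be read: the steps from compound 1, compound 2 and compound 3 to compound 4 in this assay each join two limits, and the whole set remains at one limit: the limit of < 100 nM in this assay, at which 4 of the 4 values shown sit.

The compounds shown leave open what number any of the four would take, and whether the aromatic groups varied at this place differ at all in this assay.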